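From 2,4-dimethylphenyl to 4-methoxyphenyl on the sulfonamide nitrogen

A few compounds are considered here, and "the series" means these few. Any claim that something is new, unique, unknown or untested is made for them only; others in the source may bear on it.

Values measured in a functional assay on M21 cells (Homo sapiens) for antiproliferative activity, read by sulforhodamine B assay, with a stated time of 48 h; on this read-out lower numbers stand for stronger inhibition and higher numbers for weaker inhibition
Compound 1 (`O=C1NCCN1c1ccc(S(=O)(=O)Nc2ccc(C3CCCCC3)cc2)cc1`) gives > 1000 nM (a limit)
Compound 2 (`Cc1cc(C)cc(NS(=O)(=O)c2ccc(N3CCNC3=O)cc2)c1`) gives 63 nM
Compound 3 (`Cc1ccc(NS(=O)(=O)c2ccc(N3CCNC3=O)cc2)c(C)c1`) gives 150 nM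

In this assay compound 3 stands at 150 nM as the higher of the two numbers, with compound 2 the nearest and lower at 63 nM in the same read-out. Compound 1 gives only a limit (> 1000 nM). Compound 4 (`COc1ccc(NS(=O)(=O)c2ccc(N3CCNC3=O)cc2)cc1`) has 4-methoxyphenyl in place of 2,4-dimethylphenyl on a sulfonamide nitrogen. Within the data shown here, the one measured step bearing on this change also swaps the group on that nitrogen (a 2.4-fold higher number from compound 2 to compound 3 (0.38 log units; beyond the scatter)) and it is modest. A step of similar modest size toward a higher number is expected in this assay (a 2.1-fold higher number from compound 3 to compound 4 (0.33 log units; beyond the scatter)). The estimate for compound 4 is 320 nM with an expected range from 100 nM to 1000 nM in this read-out.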

Compound 4, half-maximal inhibitory concentration: 580 nM
The estimate for compound 4 lay 1.8-fold (0.26 log units) below the measured number; the measured number falls inside the stated range.
By their numbers in this assay, from the lowest: compound 2; then compound 3; then compound 4. At a limit, above all of these: compound 1.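

In this assay, the group on the sulfonamide nitrogen matters beyond the placing of two methyl groups, since 4-methoxyphenyl carries the number further up than either dimethylphenyl: a 3.9-fold higher number from compound 3 to compound 4 (0.59 log units; beyond the scatter), and a 9.2-fold higher number from compound 2 to compound 4 (0.96 log units; beyond the scatter). Compound 1 gives only a limit. The step that involves it is therefore a floor and no more: an at least 1.7-fold lower number from compound 1 to compound 4 (0.23 log units; that floor lies within the scatter). Nothing measured here accounts for the rise.

The compounds shown leave open how a plain phenyl would compare on that nitrogen. They also leave open what a phenyl carrying an amine or a carboxylic acid would do.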